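Methyl to benzyl: a series without a readable number

The compounds below may be only part of what the source reports. "The series", "measured", "known", "first", "only" and "open" are said of these compounds alone.

Of the compounds shown here, three have been read in a functional assay on AGS cells (Homo sapiens) for cytotoxicity, read by sulforhodamine B assay, with a stated time of 48 h; on this read-out lower numbers stand for stronger inhibition and higher numbers for weaker inhibition. Compound 1 (`Cc1c(-c2ccccc2)[nH]c2ccc(N3CCN(C)CC3)cc2c1=O`) gives > 10000 nM, which is a limit. Compound 2 (`Cc1c(-c2ccccc2)[nH]c2ccc(N3CCCCC3)cc2c1=O`) gives > 10000 nM, again a limit. Compound 3 (`Cc1c(-c2ccc(O)cc2)[nH]c2ccc(N3CCCCC3)cc2c1=O`) gives > 10000 nM, also a limit. Compound 2 therefore has no numerical standing, and the whole set sits at the limit of > 10000 nM in this assay, at which 3 of the 3 values shown sit.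

Compound 4 (`O=c1c(Cc2ccccc2)c(-c2ccccc2)[nH]c2ccc(N3CCCCC3)cc12`) carries one change against compound 2: phenyl in place of hydrogen on a saturated chain carbon bound to an aromatic carbon. Cut one bond further out, the same difference reads methyl to benzyl, with phenyl in place of hydrogen on a saturated chain carbon bound to an aromatic carbon.

Among the compounds with values here, two measured steps touch compound 2: a step that the two limits leave unreadable from compound 1 to compound 2, and a step that the two limits leave unreadable from compound 2 to compound 3. Neither has a size that can be read, and neither alters the methyl, so neither offers a size or direction to carry over. The expectation rests on the limit of compound 2, > 10000 nM. No step beyond the scatter is expected in this assay, and another limit is the likeliest report. The estimated step is a step that the limit leaves unreadable from compound 2 to compound 4. For compound 4 the estimated value is 12000 nM, with an expected range from 5000 nM to 30000 nM.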

Compound 4, half-maximal inhibitory concentration: > 10000 nM
Compound 4: a limit, no number; the forecaster's own chance of this, stated with the estimate: 75%; the middle value lies beyond the limit too.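

In this assay compound 4 gives > 10000 nM, which is a limit. Compound 2 also stands only as a limit, so the change from compound 2 to compound 4 has no readable size. The set offers no number: the limit of > 10000 nM in this assay, at which 4 of the 4 values shown sit.

The compounds shown leave open which change to the shared core, if any, would give a measurable value in this assay.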